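Aryl swaps on the ring nitrogen: cytotoxicity notes

The source may report more compounds than this note shows. Statements on the series, on what has been measured and on what is new or still open speak of the compounds shown alone.

Measured so far:
compound 1 `COc1ccc(/C=C\C(=O)O)c(OCc2cn(-c3ccccc3C#N)nn2)c1CC=C(C)C`: 38300 nM
compound 2 `COc1ccc(/C=C\C(=O)O)c(OCc2cn(-c3ccc(CO)cc3)nn2)c1CC=C(C)C`: 31700 nM

In a functional assay on HCT-116 cells (Homo sapiens) for cytotoxicity, read by MTT assay, with a stated time of 24 h (on this read-out higher numbers stand for weaker inhibition and lower numbers for stronger inhibition), compound 1 gives 38300 nM and compound 2 gives 31700 nM. For the measured compounds named here, the single step between them, a 1.2-fold lower number from compound 1 to compound 2 (0.08 log units; within the scatter), leaves compound 2 with the lower of the two numbers, but the gap is within the scatter, so neither compound can be told apart from the other on this assay.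

Compound 3 `COc1ccc(/C=C\C(=O)O)c(OCc2cn(-c3cccc(C#N)c3)nn2)c1CC=C(C)C` differs from compound 2 by 3-cyanophenyl in place of 4-(hydroxymethyl)phenyl on an aromatic nitrogen. Going by the values given here, the one measured step bears on this directly: the move from 2-cyanophenyl to 4-(hydroxymethyl)phenyl, a 1.2-fold lower number from compound 1 to compound 2 (0.08 log units; within the scatter), stayed within the scatter, and compound 3 now returns a cyanophenyl ring in the 3-position. Among the compounds with values here, with compound 1 at 38300 nM and no step so far beyond the scatter, the step of a 1.1-fold higher number from compound 2 to compound 3 (0.04 log units; within the scatter) is expected to be small, in no clear direction. Compound 3 is therefore estimated at 35000 nM, within 15000 nM to 80000 nM on this assay.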

Compound 3, half-maximal inhibitory concentration: 35300 nM
For compound 3 the middle estimate is 1.0-fold (0.00 log units) below the measured one, within the range that was stated.
By their numbers in this assay, from the lowest: compounds 2, 3 and 1 (each within the scatter of the next).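

In this assay, 3-cyanophenyl in place of 2-cyanophenyl gives a 1.1-fold lower number from compound 1 to compound 3 (0.04 log units; within the scatter) and so, for this pair carrying the nitrile at two different ring places, the aryl group on the aromatic nitrogen shows no separable difference. 3-Cyanophenyl in place of 4-(hydroxymethyl)phenyl gives a 1.1-fold higher number from compound 2 to compound 3 (0.05 log units; within the scatter) and thus exchanging the hydroxymethyl, with its hydrogen-bond donor, for a nitrile also leaves the compounds inseparable on this read-out. No supporting data accompany these steps, so nothing explains this flatness.

The compounds shown leave open whether an amine or a carboxylic acid on this aryl ring, or a longer chain in place of the hydroxymethyl, would give a step beyond the scatter. Also open is how 4-cyanophenyl would compare with the two cyanophenyl groups shown.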